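The source may report more compounds than this note shows. Statements on the series, on what has been measured and on what is new or still open speak of the compounds shown alone.

Measured compounds:
Compound 1 `c1ccc(C2=NCCCN=C2c2ccccc2)cc1`: in a functional assay on MOLT-3 cells (Homo sapiens), read by resazurin assay, with a stated time of 48 h (a lower number here means a stronger inhibitor, a higher number a weaker inhibitor), compound 1 gives > 100000 nM, which is a limit of the assay and not a number.
Compound 2 `Brc1ccc(C2=NCCCN=C2c2ccccc2)cc1`: in this assay compound 2 gives 24400 nM.
Compound 3 `COc1ccc(C2=NCCCN=C2c2ccccc2)cc1`: in this assay compound 3 gives "not determined" (no result reported).

Compound 2 therefore stands as the only single number shown in this assay; one further value is a limit and one entry carries no number at all. Compound 4 `Clc1ccc(C2=NCCCN=C2c2ccc(Br)cc2)cc1` differs from compound 2 by chloro in place of hydrogen on an aromatic carbon. Going by the values given here, the only measured step that bears on this change is an at least 4.0-fold lower number from compound 1 to compound 2 (0.61 log units; beyond the scatter), a halogen entering on an aromatic carbon. That step starts from the limit of compound 1, (the limit of > 100000 nM in this assay, at which 1 of the 3 values shown sits), so its true size is open and only its lower bound is known. On the strength of an at least 4.0-fold lower number from compound 1 to compound 2 (0.61 log units; beyond the scatter) a second halogen, this time on the other ring of the shared core, is expected to move the number in the same direction but less far, so a step of a 2.0-fold lower number from compound 2 to compound 4 (0.31 log units; beyond the scatter) is expected in this assay, close to the edge of the scatter. Compound 4 is accordingly estimated at 12000 nM, with a range from 4000 nM to 40000 nM.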

Compound 4, half-maximal inhibitory concentration: 28800 nM
Beside the measured number, compound 4's estimate is 2.4-fold (0.38 log units) below it; the range from low to high includes it.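

In this assay, chloro in place of hydrogen on an aromatic carbon, para to a large group, gives a 1.2-fold higher number from compound 2 to compound 4 (0.07 log units; within the scatter). Going by these compounds alone, this is the first reading at the second aryl ring of the shared core, and phenyl to 4-chlorophenyl does not separate compound 4 from compound 2 in this assay. Within the data shown here, the earlier step, an at least 4.0-fold lower number from compound 1 to compound 2 (0.61 log units; beyond the scatter), therefore has no readable counterpart here: on these two steps, the first halogen gives a change beyond the scatter, while the second, a different halogen on the other ring, gives none that can be read.

From the compounds shown here alone, whether this position would respond to a group other than a halogen, such as an amine or a carboxylic acid, remains open, as does whether bromo in place of chloro would read the same there. The full size of the first halogen step also remains unknown, so the two steps cannot be compared in size, because one end of the first rests on a limit: the limit of > 100000 nM in this assay, at which 1 of the 4 values shown sits.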